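Triazole and isoxazole nucleosides: cytotoxicity on HCT-15 cells

The source may report more compounds than this note shows. Statements on the series, on what has been measured and on what is new or still open speak of the compounds shown alone.

Measured so far:
compound 1 `CC(C)(C)c1ccc(Cn2cc(-c3cn([C@H]4C[C@H](O)[C@@H](CO)O4)c(=O)[nH]c3=O)nn2)cc1` gives 96.9%
compound 2 `CC(=O)OC[C@H]1O[C@@H](n2cc(-c3cc(C)no3)c(=O)[nH]c2=O)C[C@@H]1OC(C)=O` gives 102%

Both numbers come from a functional assay on HCT-15 cells (Homo sapiens) for cytotoxicity, read by sulforhodamine B assay, tested at 10 uM; a lower number here means less inhibition, a higher number more inhibition at the concentration tested (going by the name of the read-out). Compound 2 holds the higher of the two values, but its gap to compound 1 lies within the usual scatter, so the two compounds cannot be placed in an order. Among the measured compounds shown here, no step between measured compounds that differ in a single place is available.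

Compound 3 `CC(=O)OC[C@H]1O[C@@H](n2cc(-c3cc(-c4ccc(C(C)(C)C)cc4)no3)c(=O)[nH]c2=O)C[C@@H]1OC(C)=O` is not yet measured. It differs from compound 2 in one place: 4-(tert-butyl)phenyl in place of methyl on an aromatic carbon. Because compound 1 already bears a tert-butyl group on an aromatic ring and gives 96.9%, while compound 2 gives 102%, no step beyond the scatter is expected in either direction. The step from compound 2 to compound 3 is estimated as a number 5 percentage points lower from compound 2 to compound 3 (within the scatter). In this assay compound 3 is expected to give 97%, with a range from 80% to 105%.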

Compound 3, a percentage reported as inhibition, at one concentration (the size of the read-out at that concentration, not a potency): 53.8%
For compound 3 the middle estimate is 43.2 percentage points above the measured one; measured number below the stated range.
By their numbers in this assay, from the lowest: compound 3; then compounds 1 and 2 (each within the scatter of the next).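

The read-out in this assay shows a number 48.2 percentage points lower from compound 2 to compound 3 (beyond the scatter) when 4-(tert-butyl)phenyl replaces methyl on an aromatic carbon of the five-membered aromatic ring with 1 nitrogen and 1 oxygen, next to the ring nitrogen. This first readable single-change step shows that the group at this position matters for inhibition at the concentration tested, and that the shared core alone does not fix the result, although compound 3 keeps a measurable 53.8% of inhibition. Nothing at hand indicates what lies behind this step.

Still open, as far as these compounds go, is whether the step follows the phenyl ring or its tert-butyl group, which an unsubstituted phenyl at the same position would separate. Also open, from the compounds shown here alone, is how an aminomethyl group or a carboxylic acid would read there.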